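Swapping an Acetyl for a Methylsulfonyl Group

The compounds below may be only part of what the source reports. "The series", "measured", "known", "first", "only" and "open" are said of these compounds alone.

Of the compounds shown here, three have so far been tested in an assay on HEK293 cells for displacement of a labelled ligand from Translocator protein (Homo sapiens), read by scintillation counting, with a stated time of 90 min; a lower number here means a stronger inhibitor, a higher number a weaker inhibitor. Compound 1 `CCN(CC)C(=O)c1nc2ccccc2n1Cc1ccc(OC)nc1` reaches only the limit of this assay, > 10000 nM. Compound 2 `CCN(CC)C(=O)c1cc2cc(C)ccc2n1Cc1ccc(OCc2ccccc2)cc1` likewise stops at the limit, > 10000 nM. Among the measured compounds shown here, compound 3 `C#CCN(C)C(=O)c1cc2cc(NC(C)=O)ccc2n1Cc1ccc(OC)cc1` is the only one of the three to give a measurable number, 2860 nM, so it stands alone as the single real reading in this set. Compound 4 `C#CCN(C)C(=O)c1cc2cc(NS(C)(=O)=O)ccc2n1Cc1ccc(OC)cc1` differs from compound 3 in one place: methylsulfonyl in place of acetyl on a nitrogen on an aromatic ring. For the measured compounds named here, no measured pair in this set shows what such a swap does, so there is no basis for expecting a shift beyond the usual scatter in either direction. Compound 4 is therefore expected to land close to the measured value of its parent, at an estimated 3500 nM (range 1200 nM to 10000 nM). The expected step is a 1.2-fold higher number from compound 3 to compound 4 (0.09 log units; within the scatter).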

Compound 4, inhibition constant: 761 nM
Estimate against measurement, compound 4: 4.6-fold (0.66 log units) above, and the stated range ends above it.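

In this assay, among the compounds shown here, the swap gives a 3.8-fold lower number from compound 3 to compound 4 (0.57 log units; beyond the scatter) in the first pair that differs in only one place. This shows that the group on this nitrogen affects the reading and that methylsulfonyl is tolerated there, although the step is modest and rests on one pair. Few exact readings are available for setting this result in context: the limit of > 10000 nM in this assay, at which 2 of the 4 values shown sit.

Going by these compounds, whether a longer chain such as ethylsulfonyl would lower the number further remains open. So does whether the same swap would act alike on a different core.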